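Adding the guanidine tail on a second sulfonamide core

A few compounds are considered here, and "the series" means these few. Any claim that something is new, unique, unknown or untested is made for them only; others in the source may bear on it.

Measured in a functional assay on MCF7 cells (Homo sapiens) for cytotoxicity, read by sulforhodamine B assay, with a stated time of 48 h; a lower number here means a stronger inhibitor, a higher number a weaker inhibitor:
compound 1, `NS(=O)(=O)c1ccc(Nc2ncnc3ccccc23)cc1`, gives 2.4 ug/mL
compound 2, `N=C(N)NS(=O)(=O)c1ccc(Nc2ncnc3ccccc23)cc1`, gives 1.85 ug/mL
compound 3, `NS(=O)(=O)c1ccc(NC2=NS(=O)(=O)c3ccccc32)cc1`, gives 4.17 ug/mL

Compound 2 arises from compound 1 by a single change, (a group of 3 heavy atoms (1 carbon, 2 nitrogen; no ring) in place of a hydrogen atom, on a sulfonamide nitrogen), and that change produced a 1.3-fold lower number from compound 1 to compound 2 (0.11 log units; within the scatter). Compound 3 rests on a different core; the difference between the two cores is not broken down here. Its number in this assay is the highest of the three, yet it lies within the scatter of compound 1 and differs beyond the scatter only from compound 2.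

Compound 4, `N=C(N)NS(=O)(=O)c1ccc(NC2=NS(=O)(=O)c3ccccc32)cc1`, has not yet been measured. Going by the values given here, it is built from compound 3 by a group of 3 heavy atoms (1 carbon, 2 nitrogen; no ring) in place of a hydrogen atom, on a sulfonamide nitrogen, which is the same change, at the same place, as the one turning compound 1 into compound 2. The step expected from compound 3 to compound 4 is estimated as a 1.3-fold lower number from compound 3 to compound 4 (0.11 log units; within the scatter), a small move of about the earlier size, because the earlier step was a 1.3-fold lower number from compound 1 to compound 2 (0.11 log units; within the scatter). On that basis compound 4 is expected to give roughly 3.2 ug/mL in this assay, most likely between 1.6 ug/mL and 6.5 ug/mL.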

Compound 4, half-maximal inhibitory concentration: 4.3 ug/mL
For compound 4 the middle estimate is 1.3-fold (0.13 log units) below the measured one; low and high end bracket the measured number.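

Placing the guanidine tail on the sulfonamide nitrogen of compound 3 gives a 1.0-fold higher number from compound 3 to compound 4 (0.01 log units; within the scatter) in this assay. Set beside the same change on the core of compound 1, the two steps do not differ by more than repeated measurement would allow: the same change on two cores in this assay, a 1.3-fold lower number (0.11 log units; within the scatter) from compound 1 to compound 2 and a 1.0-fold higher number (0.01 log units; within the scatter) from compound 3 to compound 4, 1.3-fold (0.13 log units) apart, within the scatter of two such steps. The change therefore behaves alike on these two cores, leaving the number within the scatter each time, but neither step stands clear of that scatter, so this does not show that the tail truly strengthens or weakens the compounds, and two cores cannot speak for the whole series.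

The compounds shown leave open what other groups on that sulfonamide nitrogen would do, such as a methyl group, an acetyl group or a longer alkyl chain. They also leave open whether a simple amine or a carboxylic acid in place of the guanidine tail would give a step large enough to read.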